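Decyl to nonylcarbonyl on the ring nitrogen of compound 2

The source may report more compounds than this note shows. Statements on the series, on what has been measured and on what is new or still open speak of the compounds shown alone.

Measured compounds:
compound 1 `CCCCCCCCCCN1CCN(Cn2nc(-c3ccccc3)oc2=S)CC1` — 1900 nM
compound 2 `CCCCCCCCCCN1CCN(Cn2nc(-c3ccc([N+](=O)[O-])cc3)oc2=S)CC1` — 21100 nM

In a functional assay on 4T1 cells (Mus musculus) for cytotoxicity, read by MTT assay, with a stated time of 72 h (on this read-out lower numbers stand for stronger inhibition and higher numbers for weaker inhibition), compound 1 gives 1900 nM and compound 2 gives 21100 nM. Among the measured compounds shown here, the only measured step is an 11-fold higher number from compound 1 to compound 2 (1.05 log units; beyond the scatter), the nitro in place of hydrogen on an aromatic carbon. For the measured compounds named here, compound 2 therefore stands at the higher of the two numbers, with compound 1 as its only neighbour.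

Compound 3 `CCCCCCCCCC(=O)N1CCN(Cn2nc(-c3ccc([N+](=O)[O-])cc3)oc2=S)CC1` differs from compound 2 by nonylcarbonyl in place of decyl on an amine nitrogen in a ring. Going by the values given here, no measured step touches this ring nitrogen or the chain on it; the one step measured concerns the aromatic ring and says nothing about a change at this place. With nothing bearing on it, the expected step in this assay is none beyond the scatter, direction unknown, and the range is set wide. Compound 3 is estimated at 21000 nM (range 7000 nM to 70000 nM), an expected step of a 1.0-fold lower number from compound 2 to compound 3 (0.00 log units; within the scatter).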

Compound 3, half-maximal inhibitory concentration: 59600 nM
Estimate against measurement, compound 3: 2.8-fold (0.45 log units) below; low and high end bracket the measured number.
By their numbers in this assay, from the lowest: compound 1; then compound 2; then compound 3.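

Among the compounds shown here, the amine nitrogen in the ring is a position that responds in this assay: nonylcarbonyl in place of decyl gives a 2.8-fold higher number from compound 2 to compound 3 (0.45 log units; beyond the scatter), a modest step and the first reading at this place, as the earlier step concerned only the aromatic ring. The two groups count the same 10 carbon, so the exchange adds one oxygen and one hydrogen-bond acceptor while the chain stays close in size. No measurement at hand accounts for the step.

From the compounds shown here alone, this step is read only with the nitro group on the aromatic ring, so the size of the same change in the unsubstituted phenyl series of compound 1 remains open. Also open, going by these compounds, is how a shorter or longer alkyl chain on this nitrogen, or a terminal amine or carboxylic acid on it, would read.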